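The compounds below may be only part of what the source reports. "The series", "measured", "known", "first", "only" and "open" are said of these compounds alone.

Of the compounds shown here, three have been measured in an ADME assay on microsomes from liver (Homo sapiens) for metabolic stability, read by LC-MS, with a stated time of 40 min, tested at 0.5 uM; on this read-out lower numbers stand for slow clearance and higher numbers for fast clearance. Compound 1 (`CC(C)(C)NS(=O)(=O)c1cccc(NC(=O)c2ccc(NC3(CO)CC3)cc2N2CCC3(CC2)CC3)n1`) gives 83 mL.min-1.g-1. Compound 2 (`CC(C)(C)NS(=O)(=O)c1cccc(NC(=O)c2cccnc2N2CCC3(CC2)CC3)c1`) gives no number, only a limit, > 399 mL.min-1.g-1. Among the measured compounds shown here, compound 2 is thus the one compound sitting at the limit of > 399 mL.min-1.g-1 in this assay, at which 1 of the 3 values shown sits.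

Compound 4 (`O=C(Nc1cccc(S(=O)(=O)N2CCCC2)c1)c1cccnc1N1CCC2(CC1)CC2`) keeps the rest of compound 2 and exchanges a single group, with pyrrolidin-1-yl in place of (tert-butyl)amino on a sulfonyl sulfur. For the measured compounds named here, no measured pair shows this exchange, so the guidance is thin. The closest hint comes from compound 3 (`O=C(Nc1cccc(S(=O)(=O)N2CCCCC2)c1)c1cn[nH]c1-c1ccc(Cl)cc1`), which also carries a ring on its sulfonyl sulfur, though on a different core, and gives 255 mL.min-1.g-1. On that hint, clearance is expected to stay fast in this assay. The estimated step of an at least 1.3-fold lower number from compound 2 to compound 4 (0.12 log units; that floor lies within the scatter) is modest and points toward slower clearance, although the reading could also land at the limit again. Compound 4 is expected at 300 mL.min-1.g-1, with an estimated range from 130 mL.min-1.g-1 to 550 mL.min-1.g-1.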

Compound 4, intrinsic clearance in microsomes: > 399 mL.min-1.g-1
Compound 4: no number, only a limit (the forecaster's own chance of this, stated with the estimate: 35%); middle value at least 1.3-fold (0.12 log units) from the limit.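

In this assay compound 4 gives > 399 mL.min-1.g-1, which is a limit and not a number. Compound 2 also stands at a limit, so no step can be read between compound 2 and compound 4. The compounds shown leave open whether pyrrolidin-1-yl in place of (tert-butyl)amino on a sulfonyl sulfur changes clearance at all.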